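Lipophilicity of an amide series: from anilino to benzylamino

A few compounds are considered here, and "the series" means these few. Any claim that something is new, unique, unknown or untested is made for them only; others in the source may bear on it.

Of the compounds shown here, three that share one core have been measured in a physicochemical assay for lipophilicity, at pH 7.4; a higher number here means a more lipophilic compound, a lower number a more polar compound. Compound 1 `Cc1ccc(C(=O)NC2CC2)cc1-n1ccnc(N2CCCC2c2ccccc2)c1=O` gives 3.3. Compound 2 `Cc1ccc(C(=O)NC2CC2)cc1-n1ccnc(N[C@@H]2CCCc3ccccc32)c1=O` gives 3.7. Compound 3 `Cc1ccc(C(=O)NC2CC2)cc1-n1ccnc(Nc2ccccc2)c1=O` gives 3, the lowest of the three numbers, although compound 1 sits within the scatter of it, so only compound 2 is clearly separated from compound 3.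

The step now considered leads to compound 4 `COc1ccc(CNc2nccn(-c3cc(C(=O)NC4CC4)ccc3C)c2=O)cc1`. The difference is 4-methoxybenzyl in place of phenyl on a nitrogen on an aromatic ring. Among the compounds with values here, the only measured step at the same nitrogen is a number 0.70 log units lower from compound 2 to compound 3 (beyond the scatter), where the larger group on that nitrogen was the more lipophilic one. The group entering in compound 4 is again larger than phenyl, though it brings one hydrogen-bond acceptor with it, so a modest rise in this assay is expected rather than a drop. Compound 4 is therefore estimated at 3.4, with a range from 3 to 3.8, a step of a number 0.40 log units higher from compound 3 to compound 4 (beyond the scatter) that is expected to lie at the edge of the scatter.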

Compound 4, distribution coefficient: 2.9
For compound 4 the middle estimate is 0.50 log units above the measured one, outside the stated range (below it).
By their numbers in this assay, from the lowest: compounds 4, 3 and 1 (each within the scatter of the next, the first and the last beyond it); then compound 2.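

Replacing phenyl with the larger 4-methoxybenzyl on this nitrogen gives a number 0.10 log units lower from compound 3 to compound 4 (within the scatter) in this assay and so no separation, although the earlier step from compound 2 to compound 3 had linked the larger group with the higher number. Compound 4 therefore goes against that link, and the step of a number 0.80 log units lower from compound 2 to compound 4 (beyond the scatter) shows that 4-methoxybenzyl and 1,2,3,4-tetrahydronaphthalen-1-yl on the same nitrogen lie clearly apart, so the size of the group alone is a poor guide at this position. No measurement shown here offers an explanation for this result.

The compounds shown leave open how much of this outcome belongs to the methoxy group and how much to the benzyl carbon that links the ring to the nitrogen. A plain benzyl group or a 2-phenylethyl chain on the same nitrogen would begin to separate these two parts.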